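The compounds below may be only part of what the source reports. "The series", "measured", "known", "first", "only" and "open" are said of these compounds alone.

Series notes.

Measured compounds:
compound 1 `O=C(CC1c2ccccc2N=C(SCCCCCN2CCCC2)N1c1ccc(-c2ccc(F)cc2)cc1)NCc1ccc(F)cc1`: 83.9%
compound 2 `O=C(CC1c2ccccc2N=C(SCCCCCN2CCCC2)N1c1ccccc1)NCc1ccc(F)cc1`: 60.1%
compound 3 `CN(C)CCCCCSC1=Nc2ccccc2C(CC(=O)NCc2ccc(F)cc2)N1c1ccccc1`: 26.7%

All three were tested in an assay on cells for inhibition of Voltage-dependent T-type calcium channel subunit alpha-1G (Homo sapiens), read by patch clamp, tested at 10 uM; on this read-out higher numbers stand for more inhibition at the one concentration tested (going by the name of the read-out) and lower numbers for less inhibition. Compound 2 serves as the reference point of the set. From compound 2 the change 4-fluorophenyl in place of hydrogen on an aromatic carbon produces the step of a number 23.8 percentage points higher from compound 2 to compound 1 (beyond the scatter). The second change from compound 2, (dimethylamino in place of pyrrolidin-1-yl on a saturated chain carbon, five bonds along the chain from a sulfur), produces a number 33.4 percentage points lower from compound 2 to compound 3 (beyond the scatter). Compound 3 therefore stands lowest of the three, with compound 2 nearest to it and compound 1 furthest away.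

Compound 4 `CN(C)CCCCCSC1=Nc2ccccc2C(CC(=O)NCc2ccc(F)cc2)N1c1ccc(-c2ccc(F)cc2)cc1` has not been measured. It differs from compound 3 by 4-fluorophenyl in place of hydrogen on an aromatic carbon, which is the same kind of change as was made from compound 2 to compound 1, and the place is described in the same words for both pairs. The two cores differ as set out under (dimethylamino in place of pyrrolidin-1-yl on a saturated chain carbon, five bonds along the chain from a sulfur).

Because the step of a number 23.8 percentage points higher from compound 2 to compound 1 (beyond the scatter) was made by this same change on the other core, a step of like size is expected for compound 4, estimated as a number 23.3 percentage points higher from compound 3 to compound 4 (beyond the scatter). This rests on a single measured pair, so the expectation is loose. In this assay compound 4 is accordingly estimated at 50%. The likely range for compound 4 is taken as 32% to 68%.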

Compound 4, a percentage reported as inhibition, at one concentration (the size of the read-out at that concentration, not a potency): 96.2%
For compound 4 the middle estimate is 46.2 percentage points below the measured one; the measured number lies above the stated range.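

In this assay, the 4-fluorophenyl change on the dimethylamino core gives a number 69.5 percentage points higher from compound 3 to compound 4 (beyond the scatter), so the direction of the earlier step carries over to this core but its size does not: the same change on two cores in this assay, a number 23.8 percentage points higher (beyond the scatter) from compound 2 to compound 1 and a number 69.5 percentage points higher (beyond the scatter) from compound 3 to compound 4, 45.7 percentage points apart, beyond the scatter of two such steps. Read the other way, the dimethylamino change reverses direction once 4-fluorophenyl is present, giving a number 12.3 percentage points higher from compound 1 to compound 4 (beyond the scatter), so the effect of either change in this series depends on what stands at the other place: the same change on two cores in this assay, a number 33.4 percentage points lower (beyond the scatter) from compound 2 to compound 3 and a number 12.3 percentage points higher (beyond the scatter) from compound 1 to compound 4, 45.7 percentage points apart, beyond the scatter of two such steps. These four compounds show that the two changes do not add up as independent increments, but they rest on a single pair per core and do not show what lies behind the dependence, nor whether it extends to any other compound in the series.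

Still open, as far as these compounds go, is whether the same dependence appears with other amines, such as piperidine or morpholine, with a shorter or longer chain to the sulfur, or with another aryl group, such as 4-chlorophenyl or pyridyl, in place of 4-fluorophenyl. From the compounds shown here alone, as these are percentages at one concentration, the relative potencies of the compounds also remain open, and concentration-response curves would be needed to settle them.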